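From Hydroxymethyl to Cyano on the Shared Core

The source may report more compounds than this note shows. Statements on the series, on what has been measured and on what is new or still open speak of the compounds shown alone.

Compound 1 (`CCCCNc1nc(N)nc2ccc(OC)cc12`) and compound 2 (`CCCCNc1nc(N)nc2ccc(CO)cc12`) share one core and differ in a single group. In an ADME assay on HEK293 cells (Homo sapiens) for cytotoxicity, with a stated time of 6 h (a higher number here means that more compound is tolerated, a lower number that less compound is tolerated), compound 1 gives > 18000 nM, which is a limit of the assay. In this assay compound 2 gives > 18000 nM, which is also a limit and not a number. Compound 2 thus stands with compound 1 at the limit of > 18000 nM in this assay, at which 2 of the 2 values shown sit.

Compound 3 (`CCCCNc1nc(N)nc2ccc(C#N)cc12`) keeps the core and the butylamino chain of compound 2, and the change is cyano in place of hydroxymethyl on an aromatic carbon. For the measured compounds named here, no measured step covers this exchange. The nearest one concerns the same place on the core, and it is a step that the two limits leave unreadable from compound 1 to compound 2, so it offers no size to carry over. With no readable step to go on, the expectation in this assay is for no shift beyond the scatter and no favoured direction. The expected step is a step that the limit leaves unreadable from compound 2 to compound 3. A further limit reading would be no surprise. The estimate for compound 3 is 20000 nM, within an expected range from 10000 nM to 40000 nM.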

Compound 3, half-maximal cytotoxic concentration: > 18000 nM
Compound 3 was reported as a limit; the forecaster's own chance of this, stated with the estimate: 80%; the middle value lies beyond the limit too.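

Compound 1, compound 2 and compound 3 all read only as a limit in this assay, so no step among these three compounds can be read: the limit of > 18000 nM in this assay, at which 3 of the 3 values shown sit.

The compounds shown leave open how far each lies beyond that limit, and whether methoxy, hydroxymethyl or cyano on this aromatic carbon makes any difference in this assay at all.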